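The source may hold more compounds than are shown below. What is called first, only, known or untested is meant among the compounds shown, and "the series" means these compounds.

Measured so far in a functional assay on MIA cells (Homo sapiens) for inhibition, read by MTT assay, with a stated time of 72 h; on this read-out higher numbers stand for weaker inhibition of growth and lower numbers for stronger inhibition of growth:
- compound 1 `N#C/C(=C\c1ccc[nH]1)C(=O)NCc1ccc(Cl)c(Cl)c1`: compound 1 gives > 50000 nM, a limit of the assay
- compound 2 `N#C/C(=C\c1ccco1)C(=O)NCc1ccc(Cl)c(Cl)c1`: compound 2 gives > 50000 nM, likewise a limit

Compound 2 stands at the limit of this assay and has no number of its own. Compound 1 stands at the same limit. The step that the two limits leave unreadable from compound 1 to compound 2 therefore cannot be read, as both values sit at the limit of > 50000 nM in this assay, at which 2 of the 2 values shown sit.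

The next compound, compound 3 `N#C/C(=C\c1ccccc1)C(=O)NCc1ccc(Cl)c(Cl)c1`, differs from compound 2 by phenyl in place of furan-2-yl on a double-bonded chain carbon bound to a double-bonded chain carbon. For the measured compounds named here, no measured step bears on this change in a readable way: the only step is the unreadable one from compound 1 to compound 2, so the data give no size and no direction for the change of the aromatic ring at this position. Compound 3 is expected to stay at the limit as well, a step that the limit leaves unreadable from compound 2 to compound 3 being the estimate. The estimate for compound 3 in this assay is 80000 nM, with a range from 20000 nM to 300000 nM.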

Compound 3, concentration for 50% growth inhibition: 47000 nM
The estimate for compound 3 lay 1.7-fold (0.23 log units) above the measured number; measured number inside the range.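

In this assay, for the compounds shown here, compound 3 gives 47000 nM, the first value that is a number and not a limit, so the position on the double-bonded chain carbon now has one readable point. Phenyl in place of furan-2-yl gives an at least 1.0-fold lower number from compound 2 to compound 3 (0.02 log units; that floor lies within the scatter), and phenyl in place of 1H-pyrrol-2-yl gives an at least 1.0-fold lower number from compound 1 to compound 3 (0.02 log units; that floor lies within the scatter); each is only a floor, and neither floor shows a change beyond the scatter. The true size of both steps stays unknown, as the other two values are limits: the limit of > 50000 nM in this assay, at which 2 of the 3 values shown sit.

On these data alone, how far compound 1 and compound 2 actually lie from compound 3 remains open. Also open, as far as these compounds go, is whether a phenyl ring carrying an amine or a carboxylic acid would give a number clearly apart from that of compound 3.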